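Thiazolidinedione to rhodanine swap on a benzylidene amide series

The source may hold more compounds than are shown below. What is called first, only, known or untested is meant among the compounds shown, and "the series" means these compounds.

Measured in a functional assay on THP-1 cells (Homo sapiens) for inhibition; on this read-out lower numbers stand for stronger inhibition and higher numbers for weaker inhibition:
compound 1 `O=C1NC(=O)/C(=C/c2ccc(C(=O)NC[C@@H]3C[C@@H](OCc4ccccc4-c4ccccc4)CN3C(=O)c3ccccc3C(=O)c3ccc(F)cc3)cc2)S1`, 320 nM
compound 2 `O=C1NC(=O)/C(=C/c2ccc(C(=O)NC[C@@H]3C[C@@H](Oc4ccccc4-c4ccccc4)CN3C(=O)c3ccccc3C(=O)c3ccc(F)cc3)cc2)S1`, 310 nM
compound 3 `O=C1NC(=S)S/C1=C\c1ccc(C(=O)NC[C@@H]2C[C@@H](Oc3ccccc3-c3ccccc3)CN2C(=O)c2ccccc2C(=O)c2ccc(F)cc2)cc1`, 660 nM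

Compound 1 and compound 2 differ in their cores; that difference between the two cores is not broken down here, and their two values lie within the scatter of each other in this assay. Compound 3 arises from compound 2 through (a group of 8 heavy atoms (4 carbon, 1 nitrogen, 1 oxygen, 2 sulfur; one five-membered non-aromatic ring with 2 hetero atoms) in place of a group of 8 heavy atoms (4 carbon, 1 nitrogen, 2 oxygen, 1 sulfur; one five-membered non-aromatic ring with 2 hetero atoms), on an aromatic carbon), and this change gave a 2.1-fold higher number from compound 2 to compound 3 (0.33 log units; beyond the scatter).

The unmeasured compound 4 `O=C1NC(=S)S/C1=C\c1ccc(C(=O)NC[C@@H]2C[C@@H](OCc3ccccc3-c3ccccc3)CN2C(=O)c2ccccc2C(=O)c2ccc(F)cc2)cc1` stands to compound 1 as compound 3 stands to compound 2: it carries a group of 8 heavy atoms (4 carbon, 1 nitrogen, 1 oxygen, 2 sulfur; one five-membered non-aromatic ring with 2 hetero atoms) in place of a group of 8 heavy atoms (4 carbon, 1 nitrogen, 2 oxygen, 1 sulfur; one five-membered non-aromatic ring with 2 hetero atoms), on an aromatic carbon, and the place of the change is described in the same words for both pairs, so it is treated as the same change on a different core. The expectation for compound 4 rests on a single precedent, the step of a 2.1-fold higher number from compound 2 to compound 3 (0.33 log units; beyond the scatter), applied to compound 1, whose value is 320 nM. On that basis compound 4 is expected to show a 2.1-fold higher number from compound 1 to compound 4 (0.32 log units; beyond the scatter) in this assay. Within the data shown here, compound 4 is therefore estimated at 670 nM, with a range from 350 nM to 1300 nM, the range being wide since only one such step is known.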

Compound 4, half-maximal inhibitory concentration: 700 nM
The estimate for compound 4 lay 1.0-fold (0.02 log units) below the measured number; the measured number falls inside the stated range.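

In this assay the swap of the five-membered ring gave a 2.2-fold higher number from compound 1 to compound 4 (0.34 log units; beyond the scatter), a modest loss of inhibition that lies beyond the scatter. Set beside the earlier step, this shows that the change carried over between these two cores with much the same size: the same change on two cores in this assay, a 2.1-fold higher number (0.33 log units; beyond the scatter) from compound 2 to compound 3 and a 2.2-fold higher number (0.34 log units; beyond the scatter) from compound 1 to compound 4, 1.0-fold (0.01 log units) apart, within the scatter of two such steps. The agreement rests on just one pair of closely related cores, and compound 1 and compound 2 themselves gave values within the scatter of each other, so it supports transfer between these two cores but not a rule for the whole series, and it does not show why the swap lowers inhibition.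

The compounds shown leave open whether the step keeps its size on a core that carries an amine or a longer chain, where the two cores here differ only slightly from each other. They also leave open how a carboxylic acid in place of the five-membered ring would compare in this assay.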